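The compounds below may be only part of what the source reports. "The series", "measured", "known", "first", "only" and "open" are said of these compounds alone.

In a functional assay on HepG2 cells (Homo sapiens) for antiproliferative activity, read by CCK-8 assay, with a stated time of 72 h (on this read-out higher numbers stand for weaker inhibition and lower numbers for stronger inhibition), compound 1 `C/C(=N\O)c1ccc(OCc2ccc(C(=O)NO)cc2)cc1` gives 7770 nM and compound 2 `O=C(/C=C/c1ccc(CN2CCc3ccccc32)cc1)NO` gives 14900 nM, two values within the usual scatter of each other. Compound 3 `Nc1ccccc1NC(=O)c1ccc(COc2ccc(Cl)cc2)cc1` gives > 32000 nM, which is a limit of the assay and not a number. So compound 3 has no measured value, only its place at the limit of > 32000 nM in this assay, at which 1 of the 3 values shown sits.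

Compound 4 `Nc1ccccc1NC(=O)c1ccc(COc2ccc(F)cc2)cc1` has not yet been measured. It differs from compound 3 by fluoro in place of chloro on an aromatic carbon, para to a large group, so that 4-chlorophenoxy becomes 4-fluorophenoxy. Within the data shown here, no measured pair shows this change, so the expectation has little to rest on. In this assay, no step beyond the scatter is expected, and neither direction is favoured. The estimated step is a step that the limit leaves unreadable from compound 3 to compound 4. This expectation rests on compound 3 at > 32000 nM, and compound 4 may well end at the same limit. The expected value for compound 4 is 35000 nM, with an estimated range from 15000 nM to 70000 nM.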

Compound 4, half-maximal inhibitory concentration: 3840 nM
Estimate against measurement, compound 4: 9.1-fold (0.96 log units) above; measured number below the stated range.
By their numbers in this assay, from the lowest: compound 4; then compounds 1 and 2 (each within the scatter of the next). At a limit, above all of these: compound 3.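

Fluoro in place of chloro, on an aromatic carbon para to a large group, gives in this assay an at least 8.3-fold lower number from compound 3 to compound 4 (0.92 log units; beyond the scatter), so a change of one heavy atom at this position moves the number beyond the scatter. Among these compounds, compound 3 stands at > 32000 nM, which is a limit of the assay and not a number, so the step has a floor but no known size: the limit of > 32000 nM in this assay, at which 1 of the 4 values shown sits. The earlier compounds offered no pair differing in one place, so this single pair is the only reading of any one change.

Only chloro and fluoro are shown at this position, so it stays open whether a hydrogen, a methoxy group or a nitrile there would side with compound 4 or compound 3. Also open, from the compounds shown here alone, is whether the same change would carry over to the core of compound 1.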